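The compounds below may be only part of what the source reports. "The series", "measured", "known", "first", "only" and "open" are said of these compounds alone.

Measured in a physicochemical assay for solubility, read by nephelometry, in phosphate buffer, measured as kinetic solubility, at pH 6.5; on this read-out higher numbers stand for higher solubility and lower numbers for lower solubility:
Compound 1 `Cc1cc(-c2ncccn2)cc(C(=O)NNS(=O)(=O)c2ccccc2)c1F`: 50 ug/mL
Compound 2 `Cc1cc(-n2cccn2)cc(C(=O)NNS(=O)(=O)c2ccccc2)c1F`: 6.3 ug/mL

Of these two numbers, compound 2 is the lower, at 6.3 ug/mL. Among the compounds with values here, the only measured step is a 7.9-fold lower number from compound 1 to compound 2 (0.90 log units; beyond the scatter), with 1H-pyrazol-1-yl in place of pyrimidin-2-yl on an aromatic carbon. Compound 3 `Cc1cc(-c2ccccn2)cc(C(=O)NNS(=O)(=O)c2ccccc2)c1F` has pyridin-2-yl in place of 1H-pyrazol-1-yl on an aromatic carbon. Within the data shown here, the same place changes, para to a fluoro group, but no compound carrying pyridin-2-yl has been measured, so the earlier step is only a loose guide. Like compound 1 at 50 ug/mL, compound 3 carries a six-membered aromatic ring there, so a rise is expected, though smaller in size than a 7.9-fold lower number from compound 1 to compound 2 (0.90 log units; beyond the scatter). The estimated step is a 2.5-fold higher number from compound 2 to compound 3 (0.40 log units; beyond the scatter). For compound 3 the expected value is 16 ug/mL, with an estimated range of 6 ug/mL to 40 ug/mL.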

Compound 3, solubility: 6.3 ug/mL
For compound 3 the middle estimate is 2.5-fold (0.40 log units) above the measured one; low and high end bracket the measured number.
By their numbers in this assay, from the lowest: compounds 2 and 3 (each within the scatter of the next); then compound 1.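

Putting pyridin-2-yl in place of 1H-pyrazol-1-yl gives no change at the digits printed from compound 2 to compound 3 (within the scatter) in this assay, so a six-membered aromatic ring at this place, para to a fluoro group, does not by itself go with the higher number. With pyridin-2-yl in place of pyrimidin-2-yl the read-out shows a 7.9-fold lower number from compound 1 to compound 3 (0.90 log units; beyond the scatter), a step of the same printed size as the one to the 1H-pyrazol-1-yl compound, which leaves pyrimidin-2-yl alone with the higher number among these three groups. Nothing measured here accounts for this difference between the two six-membered rings.

From the compounds shown here alone, what a dimethylamino group or a carboxylic acid would give at this same place stays open. So does whether the step between pyrimidin-2-yl and pyridin-2-yl would hold on a different core.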